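The source may hold more compounds than are shown below. What is called first, only, known or untested is meant among the compounds shown, and "the series" means these compounds.

Among the compounds with values here, compound 3 `CC1=C(C(=O)C2CC2)C(c2ccco2)NC(=O)N1` gives the lowest of the three numbers so far in an assay on membranes from HEK293 cells for displacement of a labelled ligand from adenosine receptor A2b (Homo sapiens), read by scintillation counting, with a stated time of 30 min (a higher number here means a weaker inhibitor, a lower number a stronger inhibitor), namely 1060 nM, though the other two stand within its scatter. Compound 1 `CCCOC(=O)C1=C(C)NC(=O)NC1c1cccs1` gives 1520 nM and compound 2 `CC1=C(C(=O)OCC(C)C)C(c2cccs2)NC(=O)N1` gives 2130 nM. Compound 4 `CC1=C(C(=O)OCC2CC2)C(c2ccco2)NC(=O)N1` carries cyclopropylmethoxy in place of cyclopropyl on a carbonyl carbon. Within the data shown here, the only measured step, a 1.4-fold higher number from compound 1 to compound 2 (0.15 log units; within the scatter), concerns a change further along the chain attached to the carbonyl and is within the scatter; no measured pair tests the entry of an oxygen on the carbonyl carbon itself. Compounds 1 and 2, whose carbonyl carbon likewise carries an oxygen, give numbers close to that of compound 3, so the step of a 1.4-fold higher number from compound 3 to compound 4 (0.15 log units; within the scatter) is expected to stay within the scatter. Compound 4 is estimated at 1500 nM, with a range from 600 nM to 4000 nM.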

Compound 4, inhibition constant: 138 nM
Beside the measured number, compound 4's estimate is 11-fold (1.04 log units) above it; the whole stated range lies above it.
By their numbers in this assay, from the lowest: compound 4; then compounds 3, 1 and 2 (each within the scatter of the next).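

Putting cyclopropylmethoxy in place of cyclopropyl on a carbonyl carbon gives a 7.7-fold lower number from compound 3 to compound 4 (0.89 log units; beyond the scatter) and so shows that this position responds to the group it carries, which the earlier step, a 1.4-fold higher number from compound 1 to compound 2 (0.15 log units; within the scatter), further along the chain, did not show. Nothing measured here accounts for the size of this step.

The compounds shown leave open whether the oxygen, the added carbon or the two together carry the step. A methoxy group or a cyclopropylmethylamino group on the same carbonyl carbon lies outside them, and compound 4 differs from compound 1 and compound 2 in more than one place.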